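The source may hold more compounds than are shown below. What is called first, only, known or untested is meant among the compounds shown, and "the series" means these compounds.

Measured compounds:
- Compound 1, `CC1=C(N2CC2)C(=O)C(C(C)C)=C(N2CC2)C1=O`, in a functional assay on L1210 cells (Mus musculus), with a stated time of 12 days (a higher number here means a more potent compound, by a factor of ten per unit of this negative logarithm, a lower number a less potent compound), compound 1 gives 5.6.
- Compound 2, `CCCC1=C(N2CC2)C(=O)C(CCC)=C(N2CC2)C1=O`, in this assay compound 2 gives 4.92.
- Compound 3, `CC1=C(N2CC2)C(=O)C(C2CCCCC2)=C(N2CC2)C1=O`, in this assay compound 3 gives 5.82.

Among these three numbers compound 3 holds the highest; compound 1 lies closest, within the scatter, while compound 2 sits well beyond it. Among the measured compounds shown here, the one step measured between two compounds that differ in a single place is a number 0.22 log units higher from compound 1 to compound 3 (within the scatter), and it stays within the scatter.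

Compound 4, `CC1=C(N2CC2)C(=O)C(N2CC2)=C(N2CC2)C1=O`, has not yet been measured. It differs from compound 3 in one place: aziridin-1-yl in place of cyclohexyl on a double-bonded ring carbon. The change sits on a double-bonded ring carbon of the shared core, next to the ring atom that bears an aziridin-1-yl group.

For the measured compounds named here, no measured step exchanges a carbon-only ring for an aziridin-1-yl group, so the step from compound 1 to compound 3 bears on it only loosely. On the numbers at hand, compound 4 is expected to reach roughly 5.9, between 5.1 and 6.7, a step of a number 0.08 log units higher from compound 3 to compound 4 (within the scatter) in this assay.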

Compound 4, logarithm of the reciprocal of the active concentration, log(1/C): 6.77
Estimate against measurement, compound 4: 0.87 log units below; the whole stated range lies below it.
By their numbers in this assay, from the lowest: compound 2; then compounds 1 and 3 (each within the scatter of the next); then compound 4.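

In this assay, this double-bonded ring carbon proves sensitive to the kind of group it carries: exchanging isopropyl for cyclohexyl stayed within the scatter, but the change to aziridin-1-yl gives a number 0.95 log units higher from compound 3 to compound 4 (beyond the scatter) when it replaces cyclohexyl and a number 1.17 log units higher from compound 1 to compound 4 (beyond the scatter) when it replaces isopropyl. Aziridin-1-yl has fewer heavy atoms than cyclohexyl, so a large carbon-only ring is not needed here for a high number. Nothing available explains why the number rises with this change.

The compounds shown leave open whether the gain is specific to aziridin-1-yl or would also appear with another nitrogen group at this place, such as a dimethylamino group or a morpholine ring. They also leave open how a simple methoxy group or a plain hydrogen would compare here.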